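A few compounds are considered here, and "the series" means these few. Any claim that something is new, unique, unknown or untested is made for them only; others in the source may bear on it.

Of the compounds shown here, two have been measured. Compound 1 `Cc1nc(N2CCCCC2)c2nnn(-c3ccc(C(C)C)cc3Br)c2n1` gives 46 nM in an in vitro assay on 293-EBNA cells for binding affinity to corticotropin-releasing factor receptor 1 (Homo sapiens); on this read-out lower numbers stand for stronger inhibition and higher numbers for weaker inhibition. Compound 2 `CCC(COC)Nc1nc(C)nc2c1nnn2-c1c(C)cc(C)cc1C` gives 59.4 nM in this assay, a number within the usual scatter of that of compound 1, so the two cannot be told apart. Compound 3 `COCCNc1nc(C)nc2c1nnn2-c1ccc(C(C)C)cc1Br` has not yet been measured; it differs from compound 1 by (2-methoxyethyl)amino in place of piperidin-1-yl on an aromatic carbon. Among the measured compounds shown here, no pair of measured compounds shows a single change of this kind, so the size of the step can only be expected, not read off. For compound 3 a modest weakening is expected, a 2.6-fold higher number from compound 1 to compound 3 (0.42 log units; beyond the scatter), with an estimate of 120 nM and a range from 40 nM to 400 nM.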

Compound 3, inhibition constant: 242 nM
The estimate for compound 3 lay 2.0-fold (0.30 log units) below the measured number; the range from low to high includes it.
By their numbers in this assay, from the lowest: compounds 1 and 2 (each within the scatter of the next); then compound 3.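

Swapping piperidin-1-yl for (2-methoxyethyl)amino on this aromatic carbon, next to the ring nitrogen, gives a 5.3-fold higher number from compound 1 to compound 3 (0.72 log units; beyond the scatter) in this assay and so shows that this position responds to the group it carries. The change removes a ring and adds a hydrogen-bond donor in one step, so these two differences cannot be separated here. Nothing measured accounts for the weaker number.

From the compounds shown here alone, whether the missing ring, the added donor or the oxygen of the chain matters most stays open. So does what morpholin-4-yl or dimethylamino would give at this position.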